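The source may hold more compounds than are shown below. What is called first, only, known or untested is meant among the compounds shown, and "the series" means these compounds.

Measured so far:
- compound 1 `O=C(Nc1nc2ccc(Cl)cc2s1)c1cn(-c2ccccc2)nc1-c1ccccc1`: 7670 nM
- compound 2 `O=C(Nc1nc2ccc(Cl)cc2s1)c1cn(-c2ccccc2)nc1-c1ccc(Cl)cc1`: 4360 nM
- compound 3 `Cc1ccc2nc(NC(=O)c3cn(-c4ccccc4)nc3-c3ccc(Cl)cc3)sc2c1`: 18600 nM

These numbers come from a functional assay on A549 cells (Homo sapiens) for cytotoxicity, read by MTT assay, with a stated time of 72 h; a lower number here means a stronger inhibitor, a higher number a weaker inhibitor. Compound 2 has the lowest number of the three, but its gap to compound 1 is within the scatter, a 1.8-fold lower number from compound 1 to compound 2 (0.25 log units; within the scatter), so the two cannot be ranked; compound 3 lies further off, a 4.3-fold higher number from compound 2 to compound 3 (0.63 log units; beyond the scatter). Compound 4 `COc1ccc(-c2nn(-c3ccccc3)cc2C(=O)Nc2nc3ccc(Cl)cc3s2)cc1` is not yet measured. It differs from compound 2 in one place: methoxy in place of chloro on an aromatic carbon. Among the compounds with values here, the only measured step at that position is the one from hydrogen to chloro, a 1.8-fold lower number from compound 1 to compound 2 (0.25 log units; within the scatter), which stayed within the scatter; the step to compound 3 touches another part of the shared core. A different group at this position is therefore expected to move this assay little, if at all. Compound 4 is estimated at 6000 nM, with a range from 2500 nM to 14000 nM, which means an expected 1.4-fold higher number from compound 2 to compound 4 (0.14 log units; within the scatter).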

Compound 4, half-maximal inhibitory concentration: 4710 nM
Compound 4: middle estimate off by 1.3-fold (0.11 log units), on the high side, and the stated range covers the measured number.
By their numbers in this assay, from the lowest: compounds 2, 4 and 1 (each within the scatter of the next); then compound 3.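

In this assay the change from 4-chlorophenyl to 4-methoxyphenyl gives a 1.1-fold higher number from compound 2 to compound 4 (0.03 log units; within the scatter) and placing methoxy on the plain phenyl ring gives a 1.6-fold lower number from compound 1 to compound 4 (0.21 log units; within the scatter) so neither step can be told apart from repeat-measurement noise. Hydrogen, chloro and methoxy at this position now all give numbers within the scatter of one another, and methoxy is a second group, after chloro, to show no clear effect there. As far as these compounds go, whether an amine, a carboxylic acid or a longer chain such as butoxy would also leave the number in that range remains open, as does whether methoxy would behave the same alongside the methyl group of compound 3. Nothing available explains why these three groups give such similar numbers.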